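Moving the chlorine around the anilino ring of compound 3

A few compounds are considered here, and "the series" means these few. Any claim that something is new, unique, unknown or untested is made for them only; others in the source may bear on it.

Compound 3 `Cc1n[nH]c2ccc(-c3nc4cnc(N5CCN(C)CC5)cn4c3Nc3ccccc3Cl)cc12` stands highest of the three compounds measured in a functional assay on MV4-11 cells (Homo sapiens) for inhibition, with a stated time of 120 h, tested at 10 uM (on this read-out higher numbers stand for more inhibition at the one concentration tested (going by the name of the read-out) and lower numbers for less inhibition), where compound 3 gives 58.1%. Compound 1 `Cc1n[nH]c2ccc(-c3nc4cnc(N5CCN(C)CC5)cn4c3Nc3ccccc3F)cc12` gives 0% and compound 2 `Cc1n[nH]c2ccc(-c3nc4cnc(N5CCN(C)CC5)cn4c3Nc3ccc(F)cc3)cc12` gives 0% in this assay. Compound 4 `Cc1n[nH]c2ccc(-c3nc4cnc(N5CCN(C)CC5)cn4c3Nc3cccc(Cl)c3)cc12` differs from compound 3 by 3-chlorophenyl in place of 2-chlorophenyl on a nitrogen on an aromatic ring. Within the data shown here, two measured steps bear on this: the step of a number 58.1 percentage points higher from compound 1 to compound 3 (beyond the scatter) and the step of a number 58.1 percentage points higher from compound 2 to compound 3 (beyond the scatter), both large, while the step of no change at the digits printed from compound 1 to compound 2 (within the scatter) shows that moving a fluorine on the same phenyl left nothing to see. Going by these compounds, the chlorine thus carries the whole effect, and its new position is untested, so compound 4 is expected to sit between the extremes, with a step of a number 28.1 percentage points lower from compound 3 to compound 4 (beyond the scatter) downward. Compound 4 is estimated at 30%, ranging from 0% to 65%.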

Compound 4, a percentage reported as inhibition, at one concentration (the size of the read-out at that concentration, not a potency): 0%
Estimate against measurement, compound 4: 30 percentage points above; the range from low to high includes it.
By their numbers in this assay, from the lowest: compounds 1, 2 and 4 (each within the scatter of the next); then compound 3.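

In this assay, the presence of chlorine alone does not account for the read-out: the step of a number 58.1 percentage points lower from compound 3 to compound 4 (beyond the scatter) shows that, with the same atoms, 3-chlorophenyl in place of 2-chlorophenyl on this nitrogen loses all of it. The steps of no change at the digits printed from compound 2 to compound 4 (within the scatter) and no change at the digits printed from compound 1 to compound 4 (within the scatter) place compound 4 with the two fluorine compounds, so among these four only the 2-chlorophenyl group stands apart. Nothing available explains this difference. Going by these compounds, whether a bromine or a methyl in place of the chlorine of compound 3 would keep the read-out stays open, as does the outcome with an unsubstituted phenyl on this nitrogen.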